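Methyl on the saturated ring of compound 2

A few compounds are considered here, and "the series" means these few. Any claim that something is new, unique, unknown or untested is made for them only; others in the source may bear on it.

Compound 2 `COc1cccc(-c2cc(C(=O)Nc3ccc(Oc4ccnc5cc(OCCCN6CCCCC6)c(OC)cc45)c(F)c3)c3cc(F)ccc3n2)c1` is the weaker of the two measured compounds: in a functional assay on MKN-45 cells (Homo sapiens) for cytotoxicity, read by MTT assay, with a stated time of 72 h (on this read-out higher numbers stand for weaker inhibition and lower numbers for stronger inhibition), compound 2 gives 690 nM. Going by the values given here, compound 1 `COc1cc2c(Oc3ccc(NC(=O)c4cc(-c5ccccc5)nc5ccc(F)cc45)cc3F)ccnc2cc1OCCCN1CCCCC1` gives 30 nM in this assay; the single measured step, a 23-fold higher number from compound 1 to compound 2 (1.36 log units; beyond the scatter), comes from a methoxy in place of hydrogen on an aromatic carbon, and that is the one change that separates the pair.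

Compound 3 `COc1cccc(-c2cc(C(=O)Nc3ccc(Oc4ccnc5cc(OCCCN6CCC(C)CC6)c(OC)cc45)c(F)c3)c3cc(F)ccc3n2)c1` differs from compound 2 by methyl in place of hydrogen on a saturated ring carbon. Among the compounds with values here, no measured step touches that part of the molecule: the only known step alters a group on an aromatic carbon, not the saturated ring, so it gives no guide to a methyl there. With nothing else to go on, the expectation is a step within the scatter, and compound 3 is expected to sit close by, with a 1.0-fold higher number from compound 2 to compound 3 (0.01 log units; within the scatter). The estimate for compound 3 in this assay is 700 nM, with a range from 250 nM to 2000 nM.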

Compound 3, half-maximal inhibitory concentration: 730 nM
Compound 3: the middle estimate sits 1.0-fold (0.02 log units) below what was measured; the measured number falls inside the stated range.
By their numbers in this assay, from the lowest: compound 1; then compounds 2 and 3 (each within the scatter of the next).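

Going from piperidin-1-yl to 4-methylpiperidin-1-yl is the first measured change at the saturated ring, and in this assay it reads a 1.1-fold higher number from compound 2 to compound 3 (0.02 log units; within the scatter). A methyl on this ring carbon, three ring bonds from the ring nitrogen, therefore leaves the number where it was, in contrast to the methoxy on an aromatic carbon, which gave a 23-fold higher number from compound 1 to compound 2 (1.36 log units; beyond the scatter); so far, the large step belongs to that aromatic change and not to the saturated ring. Nothing available on the series speaks to why the methyl makes no measurable difference here.

From the compounds shown here alone, this reading rests on a single pair that carries the methoxy, so it remains open whether 4-methylpiperidin-1-yl would also leave the number in place on the core of compound 1, which gives 30 nM in this assay. A single methyl also says little about other groups on the same ring carbon, such as a hydroxyl, an amine, a carboxylic acid or a longer chain, any of which could give a step beyond the scatter.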